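The source may report more compounds than this note shows. Statements on the series, on what has been measured and on what is new or still open speak of the compounds shown alone.

Compound 1 `Cc1cc2[nH]nc(N)c2c(=O)[nH]1`: 8%
Compound 2 `Nc1n[nH]c2cc(-c3cccnc3)[nH]c(=O)c12`: 8%
Compound 3 `COc1ccc(-c2cc3[nH]nc(N)c3c(=O)[nH]2)cc1`: 11%

All three were tested in an assay on isolated protein for inhibition of RAC-beta serine/threonine-protein kinase (Homo sapiens), read by mobility shift assay, tested at 30 uM; a higher number here means more inhibition at the concentration tested (going by the name of the read-out), a lower number less inhibition. Compound 1 and compound 2 are level at the digits shown, and together they are the lowest of the three numbers; compound 3 sits a few points higher, but within the scatter, so none of the three can be ranked against the others. Compound 4 `Nc1n[nH]c2cc(-c3cccs3)[nH]c(=O)c12` has not yet been measured. It differs from compound 1 in one place: thiophen-2-yl in place of methyl on an aromatic carbon. Compound 2 and compound 3 also replace the methyl with an aromatic ring and stay within the scatter of compound 1. For compound 4 the expected step in this assay is therefore a number 2 percentage points higher from compound 1 to compound 4 (within the scatter), nothing beyond the scatter. Compound 4 is estimated at 10%, between 0% and 25%.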

Compound 4, a percentage reported as inhibition, at one concentration (the size of the read-out at that concentration, not a potency): 5%
The estimate for compound 4 lay 5 percentage points above the measured number; low and high end bracket the measured number.
By their numbers in this assay, from the lowest: compounds 4, 1, 2 and 3 (each within the scatter of the next).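

In this assay, thiophen-2-yl in place of methyl on this aromatic carbon gives a number 3 percentage points lower from compound 1 to compound 4 (within the scatter). Adding a five-membered aromatic ring that contains sulfur at this position therefore produces no readable change in inhibition from the methyl compound. No measured evidence bears on why the step is so small.

As far as these compounds go, it remains open whether an amine, a carboxylic acid or a longer alkyl chain on this carbon would move inhibition beyond the scatter. Changes elsewhere on the shared core also remain untested among these compounds.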